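Swapping Phenyl for Methyl in a Triazene Series

The compounds below may be only part of what the source reports. "The series", "measured", "known", "first", "only" and "open" are said of these compounds alone.

In an ADME assay on MT4 cells (Homo sapiens) for cytotoxicity, read by MTT assay, with a stated time of 96 h (on this read-out lower numbers stand for higher toxicity in this test and higher numbers for lower toxicity in this test), compound 1 `COc1ccc(/N=N/N2CCCC2)cc1` gives 68000 nM. Compound 3 `Fc1ccc(F)c(/N=N/N2CCCC2)c1` reaches only a limit of the assay, > 100000 nM. Compound 2 `c1ccc(/N=N/N2CCN(c3ccccc3)CC2)cc1` gives 33000 nM, the lower of the two actual numbers, and the gap to compound 1 lies beyond the usual scatter. Compound 4 `CN1CCN(/N=N/c2ccccc2)CC1` keeps the rest of compound 2 but has methyl in place of phenyl on an amine nitrogen in a ring. Going by the values given here, no two measured compounds differ in only one place, so no measured step guides this change. With compound 2 lowest at 33000 nM, a rise is more likely than a fall in this assay. The expected step is a 1.8-fold higher number from compound 2 to compound 4 (0.26 log units; within the scatter), a small rise that may stay within the scatter. Compound 4 is estimated at 60000 nM, with an expected range from 25000 nM to 100000 nM.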

Compound 4, half-maximal cytotoxic concentration: 65000 nM
Compound 4: the middle estimate sits 1.1-fold (0.03 log units) below what was measured; the measured number falls inside the stated range.
By their numbers in this assay, from the lowest: compounds 2, 4 and 1 (each within the scatter of the next, the first and the last beyond it). At a limit, above all of these: compound 3.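

Going by these compounds alone, this is the first comparison that differs in one place only: in this assay, methyl in place of phenyl on an amine nitrogen in a ring gives a 2.0-fold higher number from compound 2 to compound 4 (0.29 log units; within the scatter). Replacing the six-carbon aromatic ring with a single carbon therefore leaves the read-out within the scatter, so this position shows no clear dependence on that ring. As far as these compounds go, what a benzyl, an acetyl or a free amine hydrogen at this position would read remains open. Readings in this series can also stop at a limit: the limit of > 100000 nM in this assay, at which 1 of the 4 values shown sits.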